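Removing a Fluorine on a Weak T-type Channel Blocker

The source may hold more compounds than are shown below. What is called first, only, known or untested is meant among the compounds shown, and "the series" means these compounds.

Compound 1 `O=C(CC1c2ccccc2N=C(SCCCCCN2CCCC2)N1c1ccc(-c2ccc(F)cc2)cc1)NCc1ccc(F)cc1` and compound 2 `O=C(CC1c2ccccc2N=C(SCCCCCN2CCCC2)N1c1ccc(-c2ccc(F)cc2)cc1)NCc1ccccc1` share one core and differ only by hydrogen in place of fluoro on an aromatic carbon. In an assay on cells for inhibition of Voltage-dependent T-type calcium channel subunit alpha-1H (Homo sapiens), read by patch clamp (on this read-out higher numbers stand for weaker inhibition and lower numbers for stronger inhibition), compound 1 gives 4880 nM, while compound 2 gives 260 nM, so that a 19-fold lower number from compound 1 to compound 2 (1.27 log units; beyond the scatter). Compound 3 `CN(C)CCCCCSC1=Nc2ccccc2C(CC(=O)NCc2ccc(F)cc2)N1c1ccccc1` is built on a different core; how the two cores differ is not broken down here. In this assay compound 3 gives 832000 nM, the highest of the three numbers. Compound 4 `CN(C)CCCCCSC1=Nc2ccccc2C(CC(=O)NCc2ccccc2)N1c1ccccc1`, not yet measured, differs from compound 3 by hydrogen in place of fluoro on an aromatic carbon, the same change that turned compound 1 into compound 2. For compound 4 the step is estimated as an 8.3-fold lower number from compound 3 to compound 4 (0.92 log units; beyond the scatter), because the same change gave a 19-fold lower number from compound 1 to compound 2 (1.27 log units; beyond the scatter). Whether this carries over to another core is uncertain, and a number this high may come back only as a limit. Compound 4 is expected to give 100000 nM, between 20000 nM and 600000 nM.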

Compound 4, half-maximal inhibitory concentration: 13800 nM
Compound 4: the middle estimate sits 7.2-fold (0.86 log units) above what was measured; measured number below the stated range.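

Swapping the 4-fluorobenzyl group for benzyl strengthens inhibition again in this assay, giving a 60-fold lower number from compound 3 to compound 4 (1.78 log units; beyond the scatter). The direction of the change therefore holds on both cores shown, but its size does not carry over unchanged: the same change on two cores in this assay, a 19-fold lower number (1.27 log units; beyond the scatter) from compound 1 to compound 2 and a 60-fold lower number (1.78 log units; beyond the scatter) from compound 3 to compound 4, 3.2-fold (0.51 log units) apart, beyond the scatter of two such steps. These two pairs do not show why the size differs, nor that the same direction would hold on any further core.

From the compounds shown here alone, only fluoro and hydrogen appear at this place on the ring, so the effect of a chlorine or a methoxy group there remains open on either core. Also open, going by these compounds, is whether a longer chain between the amide nitrogen and the ring would alter the size of the step.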